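Swapping piperidin-1-yl for isopropylamino on a shared core

The source may hold more compounds than are shown below. What is called first, only, known or untested is meant among the compounds shown, and "the series" means these compounds.

Measured so far in a functional assay (brain) for inhibition, with Rattus norvegicus as the target; on this read-out lower numbers stand for stronger inhibition and higher numbers for weaker inhibition:
- compound 1 `Cc1c(C)c2c(c(C)c1O)C(C(=O)N1CCN(C)CC1)C(C)(C)O2` gives 12000 nM
- compound 2 `Cc1c(C)c2c(c(C)c1O)C(CN1CCCCC1)C(C)(C)O2` gives 400 nM
- compound 3 `Cc1c(C)c2c(c(C)c1O)C(CN1CCN(c3ncccn3)CC1)C(C)(C)O2` gives 400 nM

Compound 2 sits level with compound 3, and the two share the lowest number of the three. Compound 1 stands far higher, well beyond the usual scatter of repeat measurements.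

Compound 4 `Cc1c(C)c2c(c(C)c1O)C(CNC(C)C)C(C)(C)O2` keeps the shared core but carries isopropylamino in place of piperidin-1-yl on a saturated chain carbon bound to a saturated ring carbon. Going by the values given here, no two measured compounds differ in only one place, so nothing here shows directly what this swap does in this assay. Still, compound 3 400 nM carries a different group on that chain carbon and reads the same as compound 2. No step beyond the scatter is therefore expected, in either direction. The expected change, a 1.3-fold higher number from compound 2 to compound 4 (0.10 log units; within the scatter), is estimated to be small. For compound 4 the estimated value is 500 nM, with an expected range from 130 nM to 2000 nM.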

Compound 4, half-maximal inhibitory concentration: 1400 nM
For compound 4 the middle estimate is 2.8-fold (0.45 log units) below the measured one, and the stated range covers the measured number.
By their numbers in this assay, from the lowest: compounds 2 and 3 (each within the scatter of the next); then compound 4; then compound 1.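

In this assay, going by these compounds alone, this is the first comparison at this chain carbon in which only one place changes, and replacing piperidin-1-yl with isopropylamino gives a 3.5-fold higher number from compound 2 to compound 4 (0.54 log units; beyond the scatter). The step lies beyond the usual scatter, so the group on this saturated chain carbon can change the read-out, and within this pair the ring-bearing piperidin-1-yl goes with the stronger inhibition. No available evidence accounts for this difference.

The swap removes a ring, lowers the heavy-atom count and adds a hydrogen-bond donor all at once, so these compounds cannot show which of those differences matters. A dimethylamino group, which has no ring and no such donor, or a pyrrolidin-1-yl group, which keeps a ring, would be needed on the same chain carbon to begin separating them.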